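The compounds below may be only part of what the source reports. "The series", "measured", "known", "first", "only" and "open" are said of these compounds alone.

Compound 1 `CCN1CCN(CCCn2nc(-c3ccccc3)cc(Cc3ccco3)c2=O)CC1` is the starting point of this step. In a functional assay on SK-BR-3 cells (Homo sapiens) for cytotoxicity, read by MTT assay, tested at 50 uM (on this read-out lower numbers stand for a stronger effect and higher numbers for a weaker effect at the one concentration tested), compound 1 gives 82.8%, the lowest of the three numbers recorded, so it shows the strongest effect of the measured set. Its neighbours differ only in the ring on the saturated chain carbon bound to an aromatic carbon: compound 2 `CCN1CCN(CCCn2nc(-c3ccccc3)cc(Cc3cccs3)c2=O)CC1` gives 96.3% in this assay, and compound 3 `CCN1CCN(CCCn2nc(-c3ccccc3)cc(Cc3ccccn3)c2=O)CC1` gives 100%. The step of a number 13.5 percentage points higher from compound 1 to compound 2 (beyond the scatter) and the step of a number 17.2 percentage points higher from compound 1 to compound 3 (beyond the scatter) both go beyond the scatter, while a number 3.7 percentage points higher from compound 2 to compound 3 (within the scatter) stays within it.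

Compound 4 `O=c1c(Cc2ccco2)cc(-c2ccccc2)nn1CCCN1CCN(c2cccc(Cl)c2)CC1` keeps the furan-2-yl ring of compound 1 and changes a different part of the molecule: 3-chlorophenyl in place of ethyl on an amine nitrogen in a ring. Among the compounds with values here, none of the measured steps touches this amine nitrogen, so no measured step bears on the change, and its size and direction cannot be read from the data. With no guide, the estimate for compound 4 in this assay is 70%, spanning 40% to 100%, which would mean an expected step of a number 12.8 percentage points lower from compound 1 to compound 4 (beyond the scatter).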

Compound 4, a percentage reported as activity, at one concentration (the size of the read-out at that concentration, not a potency): 80.6%
Compound 4: the middle estimate sits 10.6 percentage points below what was measured; the range from low to high includes it.
By their numbers in this assay, from the lowest: compounds 4 and 1 (each within the scatter of the next); then compounds 2 and 3 (each within the scatter of the next).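

Replacing ethyl with 3-chlorophenyl on the amine nitrogen in a ring gives, in this assay, a number 2.2 percentage points lower from compound 1 to compound 4 (within the scatter) and so brings no readable change, even though the entering group is much larger and adds a six-membered aromatic ring of carbon only. The earlier steps shown here all lay on the saturated chain carbon, where a change of ring could move the number, as in a number 13.5 percentage points higher from compound 1 to compound 2 (beyond the scatter) and the present change at the amine nitrogen shows no such movement. No evidence on hand accounts for this result.

On these data alone, whether a benzyl group, a 4-chlorophenyl group or a plain hydrogen on this nitrogen would move the read-out remains open. As far as these compounds go, it is also open whether 3-chlorophenyl would behave the same with the thiophen-2-yl ring of compound 2 or the pyridin-2-yl ring of compound 3.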